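A Bulkier Para Substituent on the Urea Aryl Ring

The source may hold more compounds than are shown below. What is called first, only, known or untested is meant among the compounds shown, and "the series" means these compounds.

Compound 1 `Cc1ccc(NC(=O)Nc2cccc(CNc3nccnc3Cl)c2)cc1` carries a 4-methylphenyl group on the urea nitrogen of the shared core. In a functional assay on MGC-803 cells (Homo sapiens) for antiproliferative activity, read by MTT assay, with a stated time of 48 h (on this read-out higher numbers stand for weaker inhibition and lower numbers for stronger inhibition), compound 1 gives 11900 nM, the higher of the two numbers recorded. Its nearest neighbour is compound 2 `O=C(Nc1cccc(CNc2nccnc2Cl)c1)Nc1ccccc1F`, which in this assay gives 6440 nM, so that a 1.8-fold lower number from compound 1 to compound 2 (0.27 log units; within the scatter). Compound 3 `O=C(Nc1cccc(CNc2nccnc2Cl)c1)NC1CCCCC1`, with cyclohexyl on the urea nitrogen, reaches the assay limit in this assay, reported as > 40000 nM. Because of that limit (the limit of > 40000 nM in this assay, at which 1 of the 3 values shown sits), the two steps to compound 3 are known only as bounds: an at least 3.3-fold higher number from compound 1 to compound 3 (0.52 log units; beyond the scatter), and an at least 6.2-fold higher number from compound 2 to compound 3 (0.79 log units; beyond the scatter).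

Compound 4 `CC(C)(C)c1ccc(NC(=O)Nc2cccc(CNc3nccnc3Cl)c2)cc1` is compound 1 with tert-butyl in place of methyl on an aromatic carbon. For the measured compounds named here, no measured step alters a substituent on a retained aryl ring; the aryl-to-aryl change from compound 1 to compound 2 stayed within the scatter, while both aryl-to-cyclohexyl changes lay beyond it. With the aryl ring kept intact, compound 4 is expected to move little, a 1.3-fold lower number from compound 1 to compound 4 (0.12 log units; within the scatter). Compound 4 is therefore estimated at 9000 nM, with a range from 3000 nM to 30000 nM.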

Compound 4, half-maximal inhibitory concentration: 4820 nM
Estimate against measurement, compound 4: 1.9-fold (0.27 log units) above; low and high end bracket the measured number.
By their numbers in this assay, from the lowest: compounds 4, 2 and 1 (each within the scatter of the next, the first and the last beyond it). At a limit, above all of these: compound 3.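

In this assay, the change on the aromatic carbon para to a large group gives a 2.5-fold lower number from compound 1 to compound 4 (0.39 log units; beyond the scatter). This is the first step shown that alters a substituent on a retained aryl ring and lies beyond the scatter, so a change at this position can shift the number even while the ring itself stays in place. The position takes tert-butyl, with its 4 heavy atoms against the 1 of methyl, with no loss of inhibition, but nothing shown accounts for why the number falls.

With only methyl and tert-butyl compared at this position, no trend with size can be drawn from two points. On these data alone, how an amine, a carboxylic acid or a methoxy group would fare there remains open.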